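The source may hold more compounds than are shown below. What is called first, only, known or untested is meant among the compounds shown, and "the series" means these compounds.

Of the compounds shown here, three have so far been tested in a functional assay on SGC-7901 cells (Homo sapiens) for antiproliferative activity, read by MTT assay, with a stated time of 24 h; on this read-out lower numbers stand for stronger inhibition and higher numbers for weaker inhibition. Compound 1 `Cc1ccccc1C(=O)NNC(=O)c1ccc(NS(=O)(=O)c2cnc(O)nc2O)cc1` and compound 2 `Cc1ccc(C(=O)NNC(=O)c2ccc(NS(=O)(=O)c3cnc(O)nc3O)cc2)cc1` are built on one shared core, while compound 3 `Cc1ccccc1C(=O)NNC(=O)c1ccccc1NS(=O)(=O)c1cnc(O)nc1O` is built on a second core; how the two cores differ is not broken down here. In this assay compound 1 gives > 20000 nM, which is a limit of the assay rather than a number. Compound 2 gives > 20000 nM, again a limit of the assay. Among the compounds with values here, compound 3 gives 13000 nM, the only true number among the three.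

Compound 1 and compound 2 differ in one place: 4-methylphenyl in place of 2-methylphenyl on a carbonyl carbon. The size of the step that the two limits leave unreadable from compound 1 to compound 2 cannot be read because of the limit of > 20000 nM in this assay, at which 2 of the 3 values shown sit.

Compound 4 `Cc1ccc(C(=O)NNC(=O)c2ccccc2NS(=O)(=O)c2cnc(O)nc2O)cc1` has not yet been measured. It stands to compound 3 exactly as compound 2 stands to compound 1, the same change at the same place: 4-methylphenyl in place of 2-methylphenyl on a carbonyl carbon. Within the data shown here, since the one earlier example of this change left no readable size, the expectation rests mainly on compound 3 and its 13000 nM, taken as the starting point. The step from compound 3 to compound 4 is expected to be small, a 1.2-fold higher number from compound 3 to compound 4 (0.06 log units; within the scatter), because a step that the two limits leave unreadable from compound 1 to compound 2 offers no sign of a large shift in either direction. Compound 4 is therefore estimated at 15000 nM, with a likely range from 7000 nM to 30000 nM, and a real chance that this assay reports only a limit for it.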

Compound 4, half-maximal inhibitory concentration: 15500 nM
For compound 4 the middle estimate is 1.0-fold (0.01 log units) below the measured one; the range from low to high includes it.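

In this assay, putting 4-methylphenyl in place of 2-methylphenyl on a carbonyl carbon gives a 1.2-fold higher number from compound 3 to compound 4 (0.08 log units; within the scatter), so on the core of compound 3 this change makes no difference that can be told from the ordinary spread of repeated measurements. The same change on the core shared by compound 1 and compound 2 has no readable size, because both of those values are limits of the assay and not numbers: the limit of > 20000 nM in this assay, at which 2 of the 4 values shown sit.

That leaves a single readable example of the change, which shows what it does on one core but cannot show whether that result carries over to the other, since there is no second size to set beside it.

Both methylphenyl groups are also close relatives, with the same atoms joined differently, so the compounds shown leave open whether a different group on that carbonyl carbon, such as a phenyl ring carrying an amine, a carboxylic acid or a longer chain in place of the methyl, would move the number beyond that spread. They also leave open whether any such group would bring the core of compound 1 to a value that can be read as a number.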